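Triazenes on an imidazole carboxamide core: a propyl for a thiophene

The source may hold more compounds than are shown below. What is called first, only, known or untested is meant among the compounds shown, and "the series" means these compounds.

Measured compounds:
compound 1 `COC(=O)c1cccc(/N=N/N(C)C)c1` 3.42
compound 2 `CN(/N=N/c1ccc(C(N)=O)cc1)c1cccs1` 2.9
compound 3 `CN(/N=N/c1nc[nH]c1C(N)=O)c1cccs1` 3.87

In a functional assay on L1210 cells (Mus musculus) for antiproliferative activity (a higher number here means a more potent compound, by a factor of ten per unit of this negative logarithm, a lower number a less potent compound), compound 3 gives 3.87, the highest of the three numbers. Compound 1 gives 3.42, a number lower by a gap beyond the scatter, and compound 2 gives 2.9, the lowest and furthest from compound 3, again beyond the scatter. Among the compounds with values here, no two of the measured compounds differ in a single place, so no step between them can be read off.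

Compound 4 `CCCN(C)/N=N/c1nc[nH]c1C(N)=O` has not been measured. It departs from compound 3 in one place: propyl in place of thiophen-2-yl on an amine nitrogen. Within the data shown here, with no measured pair showing the effect of exchanging a group on this amine nitrogen, the direction of the step is open. The account expects a step from compound 3 to compound 4 of a number 0.13 log units higher from compound 3 to compound 4 (within the scatter), an estimate of little change, perhaps a slight rise, at the edge of the scatter. For compound 4 the expected value in this assay is 4, estimated to lie between 3.3 and 4.7.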

Compound 4, logarithm of the reciprocal of the active concentration, log(1/C): 3.58
Beside the measured number, compound 4's estimate is 0.42 log units above it, within the range that was stated.
By their numbers in this assay, from the lowest: compound 2; then compounds 1, 4 and 3 (each within the scatter of the next, the first and the last beyond it).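

Within the data shown here, this is the first single-place change that can be read at this amine nitrogen: in this assay the exchange of thiophen-2-yl for propyl gives a number 0.29 log units lower from compound 3 to compound 4 (within the scatter) and so stays inside the usual spread of repeats. In this one pair, the five-membered aromatic ring with its sulfur can therefore give way to an open saturated chain, with no ring on this nitrogen, without a step beyond the scatter. Nothing on hand offers an explanation for how closely the two groups agree.

Whether the same exchange would give a similar step on the core of compound 2 remains open, since that core is shown here only with thiophen-2-yl. Also open, from the compounds shown here alone, is what a longer chain, a phenyl ring or a chain ending in a carboxylic acid would do on this amine nitrogen.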